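The compounds below may be only part of what the source reports. "The series", "measured", "known", "first", "only" and "open" are said of these compounds alone.

Measured so far:
Compound 1 (`CCc1ccc(/C=C/[C@@H]2CCCCN2)cc1`) gives 5.94 ug/mL
Compound 2 (`Cc1cccc(C)c1/C=C/[C@@H]1CCCCN1`) gives 7.28 ug/mL
Compound 3 (`CC(=O)c1ccc(/C=C/[C@@H]2CCCCN2)cc1`) gives 3.69 ug/mL

All three values come from a functional assay on A549 cells (Homo sapiens) for inhibition, read by MTT assay, with a stated time of 24 h (on this read-out higher numbers stand for weaker inhibition and lower numbers for stronger inhibition), and, on these numbers, compound 3 stands within the scatter of both other compounds. It lies nearest to compound 1 and furthest from compound 2, so no ranking can be drawn from them.

The next compound is compound 4 (`Cc1ccc(/C=C/[C@@H]2CCCCN2)cc1`), which has not yet been measured in this assay and carries methyl in place of acetyl on an aromatic carbon. The change sits on a six-membered aromatic ring of carbon only, para to a group of 8 heavy atoms.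

Going by the values given here, only one measured step bears on this change. It is a 1.6-fold lower number from compound 1 to compound 3 (0.21 log units; within the scatter), with acetyl in place of ethyl on an aromatic carbon. Read in reverse, that small step points to a slightly higher number when acetyl leaves, and no larger move is supported by the data. The expected change is a 1.5-fold higher number from compound 3 to compound 4 (0.17 log units; within the scatter), which means no shift beyond the scatter is expected. For compound 4 the estimated value is 5.5 ug/mL, with an expected range from 3.3 ug/mL to 9 ug/mL.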

Compound 4, half-maximal inhibitory concentration: 8.56 ug/mL
The estimate for compound 4 lay 1.6-fold (0.19 log units) below the measured number; the range from low to high includes it.
By their numbers in this assay, from the lowest: compounds 3, 1, 2 and 4 (each within the scatter of the next, the first and the last beyond it).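

In this assay, methyl in place of acetyl on this aromatic carbon gives a 2.3-fold higher number from compound 3 to compound 4 (0.37 log units; beyond the scatter) and so passes beyond the scatter, if only modestly. Going by these compounds alone, it is the only step among the three groups seen at this place to do so, which shows that the number does respond to the group on this carbon. Ethyl and methyl, however, are not separated by a 1.4-fold higher number from compound 1 to compound 4 (0.16 log units; within the scatter) and ethyl also stays within the scatter of acetyl, so the three groups do not fall into a clear series, and no measurement here offers an explanation for the gap between acetyl and methyl.

What the compounds shown leave open is whether the gap belongs to the carbonyl of acetyl or to acetyl as a whole, a question that a nitrile, a methyl ester or a carboxylic acid on the same carbon would bear on. It also remains open whether a longer chain than ethyl or an amine at this place would stay within the scatter of these compounds or move beyond it.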